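A few compounds are considered here, and "the series" means these few. Any claim that something is new, unique, unknown or untested is made for them only; others in the source may bear on it.

For the measured compounds named here, compound 2 `CC(C)C(=O)/N=C(\N)NCCCc1c[nH]cn1` holds the lowest of the two numbers so far in a functional assay on cardiac atrium for antagonist activity at histamine H2 receptor (Cavia porcellus) (a lower number here means tighter binding, a higher number weaker binding), with compound 2 giving 302 nM. Its nearest neighbour is compound 1 `CCC(=O)/N=C(\N)NCCCc1c[nH]cn1`, which in this assay gives 347 nM; the step of a 1.1-fold lower number from compound 1 to compound 2 (0.06 log units; within the scatter) falls within the scatter, so the two cannot be ordered. Compound 3 `CCCC(=O)/N=C(\N)NCCCc1c[nH]cn1` differs from compound 2 only by propyl in place of isopropyl on a carbonyl carbon, the same atoms joined differently. Going by the values given here, the single measured step that bears on this branch point is the one from compound 1 to compound 2, where methyl in place of hydrogen on the saturated chain carbon bound to the carbonyl carbon left the number essentially unchanged. Compound 3 is therefore expected to sit with compound 2, its step of a 1.1-fold higher number from compound 2 to compound 3 (0.03 log units; within the scatter) estimated to stay within the scatter. The estimate for compound 3 in this assay is 320 nM, with a range from 150 nM to 700 nM.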

Compound 3, dissociation constant: 407 nM
For compound 3 the middle estimate is 1.3-fold (0.10 log units) below the measured one; the range from low to high includes it.
By their numbers in this assay, from the lowest: compounds 2, 1 and 3 (each within the scatter of the next).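

In this assay, moving from isopropyl to propyl on the carbonyl carbon, with the same atoms joined differently, gave a step within the scatter (a 1.3-fold higher number from compound 2 to compound 3 (0.13 log units; within the scatter)), so a branched and a straight chain at this position cannot be told apart. The methyl in place of hydrogen, tested earlier only on the chain carbon bound to the carbonyl carbon, also left the number within the scatter when placed two bonds along the chain (a 1.2-fold higher number from compound 1 to compound 3 (0.07 log units; within the scatter)), and the three compounds therefore cannot be ordered. No evidence is available on why these values lie so close.

Going by these compounds, it remains open whether a longer chain such as butyl, or a phenyl ring, on this carbonyl carbon would carry the number beyond the scatter. On these data alone, an amine on the chain is equally open.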